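Shifting the Methyl on the Outer Phenyl Ring

A few compounds are considered here, and "the series" means these few. Any claim that something is new, unique, unknown or untested is made for them only; others in the source may bear on it.

Compound 1 `Fc1ccccc1Nc1nc2nonc2nc1Nc1ccccc1` gives 2200 nM in an assay on mitochondria from L6 cells (Rattus norvegicus) for activation, with a stated time of 90 min; a lower number here means that less compound is needed, a higher number that more compound is needed for the effect.
Compound 2 `Fc1ccccc1Nc1nc2nonc2nc1NC1CCCCC1` gives 13400 nM.
Compound 3 `Cc1ccccc1Nc1nc2nonc2nc1Nc1ccccc1F` gives 1100 nM.

Compound 3 has the lowest number of the three, though compound 1 lies within the scatter of it, while compound 2 is clearly weaker. Compound 4 `Cc1cccc(Nc2nc3nonc3nc2Nc2ccccc2F)c1` differs from compound 3 by 3-methylphenyl in place of 2-methylphenyl on a nitrogen on an aromatic ring. For the measured compounds named here, no measured step alters the methyl in this way. The nearest guide is a 2.0-fold lower number from compound 1 to compound 3 (0.30 log units; within the scatter), which shows that adding the methyl at all changed little. The step of a 6.1-fold higher number from compound 1 to compound 2 (0.78 log units; beyond the scatter) concerns a different group and says little here. A step of about a 1.4-fold higher number from compound 3 to compound 4 (0.13 log units; within the scatter) is therefore expected for compound 4. Compound 4 is expected to give 1500 nM in this assay, likely between 500 nM and 4500 nM.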

Compound 4, half-maximal effective concentration: 1500 nM
The estimate for compound 4 equals the measured number at the digits printed; the measured number falls inside the stated range.
By their numbers in this assay, from the lowest: compounds 3, 4 and 1 (each within the scatter of the next); then compound 2.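

Moving the methyl on this nitrogen's ring, from 2-methylphenyl to 3-methylphenyl, gives a 1.4-fold higher number from compound 3 to compound 4 (0.13 log units; within the scatter) in this assay and so makes no clear difference. Against the plain phenyl, the 3-methylphenyl group also shows a 1.5-fold lower number from compound 1 to compound 4 (0.17 log units; within the scatter) and brings no clear difference. Only the exchange of cyclohexyl shows a real effect, with an 8.9-fold lower number from compound 2 to compound 4 (0.95 log units; beyond the scatter) as the result.

On these data alone, whether a methoxy group or a carboxylic acid in place of the methyl would be accepted as well remains open. No available measurement explains these numbers.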